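A few compounds are considered here, and "the series" means these few. Any claim that something is new, unique, unknown or untested is made for them only; others in the source may bear on it.

Working notes on the series. Three compounds share a core and differ only in the aryl group on the urea nitrogen. In a functional assay on K562 cells (Homo sapiens) for inhibition, read by sulforhodamine B assay, with a stated time of 48 h, tested at 0.1 uM (on this read-out higher numbers stand for a weaker effect at the one concentration tested and lower numbers for a stronger effect), compound 1 `COc1cc(Cl)cc(-c2nn(-c3cccc(NC(=O)Nc4ccc(Cl)c(C(F)(F)F)c4)c3)cc2-c2ccncc2)c1` gives 91% and compound 2 `COc1cc(Cl)cc(-c2nn(-c3cccc(NC(=O)Nc4cc(C(F)(F)F)cc(C(F)(F)F)c4)c3)cc2-c2ccncc2)c1` gives 91%; these two numbers lie within the scatter of each other. Compound 3 `COc1cc(Cl)cc(-c2nn(-c3cccc(NC(=O)Nc4ccc(Cl)c(Cl)c4)c3)cc2-c2ccncc2)c1` gives 58% in this assay, the lowest of the three, with compound 1 and compound 2 each standing well above it. The one single-point step shown is a number 33 percentage points lower from compound 1 to compound 3 (beyond the scatter), with chloro in place of trifluoromethyl on an aromatic carbon.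

Compound 4 `COc1cc(Cl)cc(-c2nn(-c3cccc(NC(=O)Nc4cccc(C(F)(F)F)c4)c3)cc2-c2ccncc2)c1` is not yet measured. The change from compound 3 is 3-(trifluoromethyl)phenyl in place of 3,4-dichlorophenyl on an amide-type nitrogen. It bears on the step from compound 1 to compound 3, which it partly reverses by restoring a trifluoromethyl group; the remaining chloro is also removed, for which no step is shown. A rise in this assay back toward the numbers of compound 1 and compound 2 is therefore expected, roughly a number 24 percentage points higher from compound 3 to compound 4 (beyond the scatter). Compound 4 is estimated at 82% in this assay, within 62% to 96%.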

Compound 4, a percentage reported as activity, at one concentration (the size of the read-out at that concentration, not a potency): 94%
Estimate against measurement, compound 4: 12 percentage points below, within the range that was stated.
By their numbers in this assay, from the lowest: compound 3; then compounds 1, 2 and 4 (each within the scatter of the next).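

In this assay, 3-(trifluoromethyl)phenyl in place of 3,4-dichlorophenyl on the amide-type nitrogen gives a number 36 percentage points higher from compound 3 to compound 4 (beyond the scatter), so the stronger effect of compound 3 does not carry over to this aryl group. Hydrogen in place of chloro gives a number 3 percentage points higher from compound 1 to compound 4 (within the scatter) and hydrogen in place of trifluoromethyl gives a number 3 percentage points higher from compound 2 to compound 4 (within the scatter), so with one trifluoromethyl present, neither the chloro nor the second trifluoromethyl shifts the number, and among these four compounds only compound 3, the one without trifluoromethyl, stands apart. Nothing shown here gives a reason for this difference.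

On these data alone, it remains open whether the lower number of compound 3 needs both chloro groups or whether a single chloro would be enough. Also open, as far as these compounds go, is how a nitrile, a methoxy group or an amine on this aryl ring would read.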